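Swapping Methoxy for Chloro on the Amide Ring

The source may hold more compounds than are shown below. What is called first, only, known or untested is meant among the compounds shown, and "the series" means these compounds.

Compound 1 `COc1ccc2c(=O)c(/C=C/C(=O)NCc3ccccc3)coc2c1`: > 100000 nM
Compound 2 `COc1ccc2c(=O)c(/C=C/C(=O)Nc3ccccc3Cl)coc2c1`: 23000 nM
Compound 3 `COc1ccc(NC(=O)/C=C/c2coc3cc(OC)ccc3c2=O)cc1`: > 100000 nM

In a functional assay (QGY7701 cells, Homo sapiens) for inhibition, read by MTT assay, with a stated time of 48 h (on this read-out higher numbers stand for weaker inhibition and lower numbers for stronger inhibition), compound 3 gives > 100000 nM, which is a limit of the assay and not a number. Two of the three values sit at that limit (the limit of > 100000 nM in this assay, at which 2 of the 3 values shown sit). Compound 4 `COc1ccc2c(=O)c(/C=C/C(=O)Nc3ccc(Cl)cc3)coc2c1` differs from compound 3 by chloro in place of methoxy on an aromatic carbon. Going by the values given here, two measured steps bear on this change: an at least 4.3-fold lower number from compound 1 to compound 2 (0.63 log units; beyond the scatter) and an at least 4.3-fold higher number from compound 2 to compound 3 (0.63 log units; beyond the scatter); the step that the two limits leave unreadable from compound 1 to compound 3 cannot be read. Compound 2, the only chloro-bearing compound measured, gives 23000 nM, the lowest number shown. A lower number than the limit is therefore expected for compound 4, though the chloro now sits at a different place. Compound 4 is expected to give about 40000 nM, between 10000 nM and 150000 nM. That estimate means an expected at least 2.5-fold lower number from compound 3 to compound 4 (0.39 log units; beyond the scatter).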

Compound 4, half-maximal inhibitory concentration: > 100000 nM
Compound 4 ended at the assay's limit; the forecaster's own chance of this, stated with the estimate: 40%; middle value at least 2.5-fold (0.39 log units) from the limit.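

Compound 4 gives > 100000 nM in this assay, a limit of the assay and not a number, and the steps to it from compound 1 and compound 3 cannot be read, as both ends are limits. Going by these compounds alone, the one readable step is an at least 4.3-fold higher number from compound 2 to compound 4 (0.63 log units; beyond the scatter). So having a chloro on the amide ring does not by itself give a measurable value here: the 2-chlorophenyl compound reads below the limit, while the 4-chlorophenyl compound does not.

Going by these compounds, whether compound 3 and compound 4 really differ stays open. So does what an amine or a carboxylic acid in place of the chloro would give.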